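The source may hold more compounds than are shown below. What is called first, only, known or untested is meant among the compounds shown, and "the series" means these compounds.

Values measured in a functional assay on HeLa S3 cells (Homo sapiens) for antiproliferative activity, read by XTT assay, with a stated time of 72 h (on this read-out lower numbers stand for stronger inhibition and higher numbers for weaker inhibition), each one a limit and not a number:

- Compound 1 `Cc1nc(N)c2c(-c3ccco3)cn([C@@H]3O[C@H](CO)[C@@H](O)[C@H]3O)c2n1` gives > 20000 nM as a limit
- Compound 2 `Cc1nc(N)c2c(-c3cccs3)cn([C@@H]3O[C@H](CO)[C@@H](O)[C@H]3O)c2n1` gives > 20000 nM as a limit
- Compound 3 `Cc1nc(N)c2c(-c3ccsc3)cn([C@@H]3O[C@H](CO)[C@@H](O)[C@H]3O)c2n1` gives > 20000 nM as a limit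

Compound 3 has no exact number in this assay and stands with the other two compounds at the same limit (the limit of > 20000 nM in this assay, at which 3 of the 3 values shown sit). The next step leads to compound 4 `Cc1nc(N)c2c(-c3ccccc3)cn([C@@H]3O[C@H](CO)[C@@H](O)[C@H]3O)c2n1`, with phenyl in place of thiophen-3-yl on an aromatic carbon. Within the data shown here, three measured steps bear on this change, each also a swap of one aromatic ring for another on an aromatic carbon: (a step that the two limits leave unreadable from compound 2 to compound 3), (a step that the two limits leave unreadable from compound 1 to compound 3) and (a step that the two limits leave unreadable from compound 1 to compound 2). None of them has a readable size, so they offer no measured change to carry over. Still, furan-2-yl, thiophen-2-yl and thiophen-3-yl all leave the read-out at the limit, and phenyl is one more aromatic ring in that place. With compound 3 at its limit (> 20000 nM) the expectation is that compound 4 will most likely be reported as a limit too. The estimated step that the limit leaves unreadable from compound 3 to compound 4 is expected to show no change beyond the scatter, in either direction. For compound 4 the estimated value is 25000 nM (expected range 10000 nM to 60000 nM).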

Compound 4, half-maximal inhibitory concentration: > 20000 nM
Compound 4 ended at the assay's limit (the forecaster's own chance of this, stated with the estimate: 85%); the middle value does not contradict the limit.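

Compound 4 also comes back only as a limit, so no step among compound 1, compound 2, compound 3 and compound 4 can be read in this assay: the limit of > 20000 nM in this assay, at which 4 of the 4 values shown sit.

The compounds shown leave open whether these four aromatic rings differ at all in this read-out, and whether any other group in that place on the shared core would give an exact value.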